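Propyl to methylsulfonyl: working notes on one solubility step

A few compounds are considered here, and "the series" means these few. Any claim that something is new, unique, unknown or untested is made for them only; others in the source may bear on it.

Measured compounds in a physicochemical assay for solubility, read by spectrophotometry, in phosphate buffer, with a stated time of 18 h, at pH 7.4 (a lower number here means a less soluble compound, a higher number a more soluble compound), so far
- compound 1 `CCc1ccc(-c2nc3c(c(C)nn3-c3ccccc3)c(-c3ccccc3C#N)c2C#N)cc1` gives 2400 nM 
- compound 2 `CCc1ccc(-c2nc3c(c(C)nn3-c3ccccc3)c(-c3ccccc3)c2C#N)cc1` gives 47000 nM 
- compound 3 `CCCc1ccc(-c2nc3c(c(C)nn3-c3ccccc3)c(-c3ccccc3O)c2C#N)cc1` gives 6500 nM 

Compound 3 stands in the middle of the three numbers, with compound 1 lower and compound 2 higher, and both gaps lie beyond the usual scatter.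

The unmeasured compound 4 `Cc1nn(-c2ccccc2)c2nc(-c3ccc(S(C)(=O)=O)cc3)c(C#N)c(-c3ccccc3O)c12` has methylsulfonyl in place of propyl on an aromatic carbon, para to a large group (methylsulfonyl in place of propyl on an aromatic carbon).

Within the data shown here, no measured step covers this change. Among the measured compounds shown here, the only step between compounds differing in one place is a 20-fold higher number from compound 1 to compound 2 (1.29 log units; beyond the scatter) with hydrogen in place of cyano on an aromatic carbon. That is a different change at a different place, so it gives no direction here. Its large size does show that one change can move the numbers far in this series, which argues for a wide range.

A small upward step, not clearly separable from the scatter, is expected on weak grounds, and a fall is not excluded. The estimated step is a 1.8-fold higher number from compound 3 to compound 4 (0.27 log units; within the scatter) in this assay as a working figure.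

The expected value for compound 4 is 12000 nM with an estimated range from 3000 nM to 45000 nM as the working span.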

Compound 4, solubility: 5000 nM
Beside the measured number, compound 4's estimate is 2.4-fold (0.38 log units) above it, within the range that was stated.
By their numbers in this assay, from the lowest: compound 1; then compounds 4 and 3 (each within the scatter of the next); then compound 2.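

In this assay, methylsulfonyl in place of propyl on an aromatic carbon, para to a large group, gives a 1.3-fold lower number from compound 3 to compound 4 (0.11 log units; within the scatter). This first reading at this position shows that a swap from an all-carbon chain to a group with oxygen, sulfur and hydrogen-bond acceptors leaves the two numbers within the scatter of each other, on the background shared by the pair, whereas a 20-fold higher number from compound 1 to compound 2 (1.29 log units; beyond the scatter), a change at a different place, stands as a large step beyond the scatter. No measured property of either group is at hand to account for this result.

The compounds shown leave open whether the same swap would read alike on the backgrounds of compound 1 and compound 2, since only one pair carries this change and a single pair cannot establish a trend. They also leave open how this position would respond to groups of another kind, such as an amine, a carboxylic acid or a longer chain, and whether any of these would give a step beyond the scatter.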